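Moving a methyl around the ring in a cinnamamide series

The source may hold more compounds than are shown below. What is called first, only, known or untested is meant among the compounds shown, and "the series" means these compounds.

Three close analogues of one anilide series have been measured, and a fourth remains to be tested. Compound 1 `Cc1ccccc1/C=C/C(=O)Nc1ccc(Cl)cc1C(N)=O` carries a 2-methylphenyl group on the double-bonded chain and a chloro substituent on the anilide ring. In a functional assay on K562 cells (Homo sapiens) for antiproliferative activity, read by trypan blue exclusion, with a stated time of 48 h, tested at 10 uM (on this read-out higher numbers stand for more inhibition of growth at the one concentration tested and lower numbers for less inhibition of growth), compound 1 gives 52.2%. Compound 2 `Cc1cccc(/C=C/C(=O)Nc2ccc(Cl)cc2C(N)=O)c1` differs from it by 3-methylphenyl in place of 2-methylphenyl on a double-bonded chain carbon bound to a double-bonded chain carbon, and in this assay compound 2 gives 37.8%, so that a number 14.4 percentage points lower from compound 1 to compound 2 (beyond the scatter). Compound 3 `Cc1ccccc1/C=C/C(=O)Nc1ccc(Br)cc1C(N)=O` keeps the 2-methylphenyl group but differs from compound 1 in its core by bromo in place of chloro on an aromatic carbon; in this assay compound 3 gives 43.2%, and a number 9 percentage points lower from compound 1 to compound 3 (within the scatter). The values of compound 2 and compound 3 lie close to one another, within the scatter.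

Compound 4 `Cc1cccc(/C=C/C(=O)Nc2ccc(Br)cc2C(N)=O)c1` has not yet been measured. It differs from compound 3 by 3-methylphenyl in place of 2-methylphenyl on a double-bonded chain carbon bound to a double-bonded chain carbon, the same change as that from compound 1 to compound 2, made on the bromo-bearing core. Since that change gave a number 14.4 percentage points lower from compound 1 to compound 2 (beyond the scatter), a step of similar size is expected here. Within the data shown here, the expected step is a number 14.2 percentage points lower from compound 3 to compound 4 (beyond the scatter), resting on the one prior example of this change and on the value of compound 3, 43.2%. Among the measured compounds shown here, with only one precedent, compound 4 is estimated in this assay at 29%, with a plausible range from 17% to 41%.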

Compound 4, percent growth inhibition at one concentration: 43.8%
Compound 4: the middle estimate sits 14.8 percentage points below what was measured; the whole stated range lies below it.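

In this assay, the move from 2-methylphenyl to 3-methylphenyl on the bromo-bearing core gives a number 0.6 percentage points higher from compound 3 to compound 4 (within the scatter), so the clear step seen on the chloro-bearing core does not carry over to this core: the same change on two cores in this assay, a number 14.4 percentage points lower (beyond the scatter) from compound 1 to compound 2 and a number 0.6 percentage points higher (within the scatter) from compound 3 to compound 4, 15 percentage points apart, beyond the scatter of two such steps

Read along the other edge of the same four compounds, bromo in place of chloro gives a number 6 percentage points higher from compound 2 to compound 4 (within the scatter) with the 3-methylphenyl group, and this step also fails to match its counterpart with the 2-methylphenyl group: the same change on two cores in this assay, a number 9 percentage points lower (within the scatter) from compound 1 to compound 3 and a number 6 percentage points higher (within the scatter) from compound 2 to compound 4, 15 percentage points apart, beyond the scatter of two such steps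

Both comparisons rest on the same four compounds and describe a single mismatch, which shows that in this set the step for the methyl move cannot be transferred from one core to the other, but it does not show why the two cores differ or whether the same would hold for other analogues in the series.

The compounds shown leave open whether a fluoro or a nitrile on the anilide ring would behave like the chloro or like the bromo core. They also leave open how a 4-methylphenyl or an unsubstituted phenyl group on the chain would compare with the two methylphenyl groups on either core.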